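Chloro for hydrogen, second occurrence in the series

The compounds below may be only part of what the source reports. "The series", "measured", "known", "first", "only" and "open" are said of these compounds alone.

Three measured compounds share one core. Compound 1, `N#Cc1c(Cl)nc(SCC(=O)Nn2c(COc3ccc(Cl)cc3Cl)nc3ccccc3c2=O)nc1-c1ccccc1`, and compound 2, `N#Cc1c(Cl)nc(SCC(=O)Nn2c(COc3ccc(Cl)cc3Cl)nc3ccccc3c2=O)nc1-c1ccc(Cl)cc1`, differ by chloro in place of hydrogen on an aromatic carbon. In a functional assay on the whole organism (strain albino) for inhibition, with Rattus norvegicus as the target, read by paw edema, with stated times of 1 h and 3 h, at a dose of 100 mg/kg by the oral route (on this read-out higher numbers stand for a stronger effect at the one dose given and lower numbers for a weaker effect), compound 1 gives 68.4%. In this assay compound 2 gives 68.4%, and the step is no change at the digits printed from compound 1 to compound 2 (within the scatter). Compound 3, `N#Cc1c(Nc2ccccc2)nc(SCC(=O)Nn2c(COc3ccc(Cl)cc3Cl)nc3ccccc3c2=O)nc1-c1ccc(Cl)cc1`, gives 56.1% in this assay; its step is a number 12.3 percentage points lower from compound 2 to compound 3 (beyond the scatter), and compound 3 stands lowest of the three. The difference between the cores of compound 1 and compound 3 is not broken down here.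

Compound 4, `N#Cc1c(Nc2ccc(Cl)cc2)nc(SCC(=O)Nn2c(COc3ccc(Cl)cc3Cl)nc3ccccc3c2=O)nc1-c1ccc(Cl)cc1`, awaits measurement in this assay. It differs from compound 3 by chloro in place of hydrogen on an aromatic carbon. The place is described in the same words as for the change from compound 1 to compound 2, so this is the same change, though cut one bond further out it reads anilino to (4-chlorophenyl)amino rather than phenyl to 4-chlorophenyl.

Compound 4 is expected near 57% because no change at the digits printed from compound 1 to compound 2 (within the scatter). The expected step is a number 0.9 percentage points higher from compound 3 to compound 4 (within the scatter), a change within the scatter. The expected range for compound 4 runs from 46% to 68%.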

Compound 4, a percentage reported as inhibition, in the whole organism at one dose (the size of the read-out at that dose, not a potency): 64.9%
Beside the measured number, compound 4's estimate is 7.9 percentage points below it; low and high end bracket the measured number.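

In this assay, chloro in place of hydrogen on an aromatic carbon gives a number 8.8 percentage points higher from compound 3 to compound 4 (within the scatter). The change behaves alike on the two cores: the same change on two cores in this assay, no change at the digits printed (within the scatter) from compound 1 to compound 2 and a number 8.8 percentage points higher (within the scatter) from compound 3 to compound 4, 8.8 percentage points apart, within the scatter of two such steps.

The second core also tolerates (4-chlorophenyl)amino in place of chloro, with a number 3.5 percentage points lower from compound 2 to compound 4 (within the scatter), so the new step adds no sign that the outcome of the chloro change depends on the core. Within the data shown here, this rests on only two cores and a single oral dose, so it gives no potency and does not show that the change is without effect, nor that it would carry to a core outside these compounds.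

The compounds shown leave open whether another group at the same place, such as fluoro, methoxy or a carboxylic acid, would carry from core to core in the same way. They also leave open how a saturated amine such as morpholine would read in place of the anilino group on the shared core.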